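Swapping the Aryl Group on a Fatty Acid Amide Hydrolase Inhibitor

This account rests on a few compounds, and the source may have more. Where it says the series, first, only, none or still open, it means among the compounds named here.

Compound 1 `Nc1cccc(-c2cnc(C(=O)CCCCCCc3ccccc3)o2)c1` carries a 3-aminophenyl group on the shared core, and in an assay (Rattus norvegicus) for inhibition of Fatty-acid amide hydrolase 1 (Homo sapiens) (on this read-out higher numbers stand for weaker inhibition and lower numbers for stronger inhibition), compound 1 gives 19 nM. Compound 2 `O=C(CCCCCCc1ccccc1)c1ncc(-c2ncccc2C(=O)O)o1` carries a 3-carboxypyridin-2-yl group in the same place. In this assay compound 2 gives only a limit, > 50 nM, so its exact number is not known. That change is an at least 2.6-fold higher number from compound 1 to compound 2 (0.42 log units; beyond the scatter), and the evidence for it rests on (the limit of > 50 nM in this assay, at which 1 of the 2 values shown sits), so compound 2 stands at the weaker end of what has been measured so far. Compound 3 `NS(=O)(=O)c1ccc(-c2cnc(C(=O)CCCCCCc3ccccc3)o2)s1` differs from compound 2 by 5-sulfamoylthiophen-2-yl in place of 3-carboxypyridin-2-yl on an aromatic carbon. For the measured compounds named here, no measured step covers this exchange directly; the only measured step, from compound 1 to compound 2, concerns a different pair of groups and shows at most how much moving away from the 3-aminophenyl group can cost. Compound 3 is therefore expected to land somewhere between the two measured points, and the step of an at least 1.2-fold lower number from compound 2 to compound 3 (0.09 log units; that floor lies within the scatter) in this assay is an estimate with wide uncertainty. For compound 3 the estimate in this assay is 40 nM, with a range from 8 nM to 200 nM.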

Compound 3, inhibition constant: 3 nM
The estimate for compound 3 lay 13-fold (1.12 log units) above the measured number, outside the stated range (below it).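

In this assay, this position, on an aromatic carbon next to the ring oxygen, can also gain strength and not only lose it: compound 3 is the strongest of the three compounds, with a 6.3-fold lower number from compound 1 to compound 3 (0.80 log units; beyond the scatter). Against the 3-carboxypyridin-2-yl group, the change gives an at least 16-fold lower number from compound 2 to compound 3 (1.22 log units; beyond the scatter), even though the leaving and entering groups have the same count of heavy atoms and of hydrogen-bond donors, so those counts alone do not set the result here. Compound 2 gives only a limit, > 50 nM, so the step from it is a floor and its true size is unknown: the limit of > 50 nM in this assay, at which 1 of the 3 values shown sits.

On these data alone, what remains open is whether the gain comes from the five-membered sulfur-containing ring or from the sulfamoyl group, as both differ from the earlier groups at once; an unsubstituted thiophen-2-yl group and a phenyl ring carrying a sulfamoyl group would pull the two apart. As far as these compounds go, it is also open whether the 5-sulfamoylthiophen-2-yl group would keep its advantage on a core with a shorter chain.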